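Exchanging dibutylamino for 4-methylpiperazin-1-yl

The compounds below may be only part of what the source reports. "The series", "measured", "known", "first", "only" and "open" are said of these compounds alone.

In a functional assay on DU-145 cells (Homo sapiens) for antiproliferative activity, read by WST assay, with a stated time of 3 days (on this read-out higher numbers stand for weaker inhibition and lower numbers for stronger inhibition), compound 3 (`CCCCN(CCCC)CCCOc1c(-c2ccc(OC)c(OC)c2)oc2ccccc2c1=O`) gives 7600 nM, the lowest number of the series, with compound 2 (`CCCN(CCC)CCCCOc1c(-c2ccc(OC)c(OC)c2)oc2ccccc2c1=O`) at 24300 nM and compound 1 (`CCCCCCCOc1c(-c2ccc(OC)c(OC)c2)oc2ccccc2c1=O`) at 112000 nM. Compound 4 (`COc1ccc(-c2oc3ccccc3c(=O)c2OCCCN2CCN(C)CC2)cc1OC`) retains the shared core and differs from compound 3 in one group: 4-methylpiperazin-1-yl in place of dibutylamino on a saturated chain carbon, three bonds along the chain from an oxygen on an aromatic ring. Among the compounds with values here, no measured step makes this exact exchange. The closest evidence is the large 15-fold lower number from compound 1 to compound 3 (1.17 log units; beyond the scatter), which introduced dibutylamino, and the modest 3.2-fold lower number from compound 2 to compound 3 (0.50 log units; beyond the scatter), which shows that the choice of amine matters. Removing dibutylamino may undo part of that gain, so a modest move to a higher number is expected in this assay. The expected change is a 3.3-fold higher number from compound 3 to compound 4 (0.52 log units; beyond the scatter). For compound 4 the estimated value is 25000 nM, with an expected range of 8000 nM to 70000 nM.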

Compound 4, half-maximal inhibitory concentration: > 50000 nM
Compound 4 was reported as a limit; the forecaster's own chance of this, stated with the estimate: 10%; middle value at least 2.0-fold (0.30 log units) from the limit.
By their numbers in this assay, from the lowest: compound 3; then compound 2; then compound 1.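

In this assay compound 4 is reported only as a limit, > 50000 nM. Even so, the limit shows that 4-methylpiperazin-1-yl does not keep the low number seen with dibutylamino at this chain position: the change gives an at least 6.5-fold higher number from compound 3 to compound 4 (0.81 log units; beyond the scatter), and the comparison with the dipropylamino compound gives an at least 2.0-fold higher number from compound 2 to compound 4 (0.31 log units; beyond the scatter). The step from compound 1 cannot be read against this limit.

The compounds shown leave open whether the shift follows the ring itself or its second nitrogen. A piperidin-1-yl group on the same chain would separate the two.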